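Replacing Methoxy with Methyl(methylsulfonyl)amino: Expected Stability

A few compounds are considered here, and "the series" means these few. Any claim that something is new, unique, unknown or untested is made for them only; others in the source may bear on it.

Three compounds sharing one core were tested in an in vitro ADME assay on microsomes from liver (Rattus norvegicus, strain Sprague-Dawley) for metabolic stability, using NADPH, with a stated time of 10 min, tested at 0.5 uM; a higher number here means that the compound lasts longer, a lower number that the compound disappears faster. Compound 1 `COc1cc(C2CCN(C[C@@H](C)O)CC2)ccc1Nc1ncc2ccc(-c3ccccc3N(C)S(C)(=O)=O)n2n1` gives 0.183 h. Compound 2 `COc1cc(C2CCNCC2)ccc1Nc1ncc2ccc(-c3ccccc3N(C)S(C)(=O)=O)n2n1` gives 0.367 h. Among the compounds with values here, the step of a 2.0-fold higher number from compound 1 to compound 2 (0.30 log units; within the scatter) is the only measured step here, and it concerns the amine nitrogen in the ring rather than the aromatic ring. Compound 3 `COc1cc(C2CCN(CC(N)=O)CC2)ccc1Nc1ncc2ccc(-c3ccccc3OC)n2n1` is known only as a limit of the assay, > 0.666 h, so its exact half-life is not fixed; the limit of > 0.666 h in this assay, at which 1 of the 3 values shown sits, marks where it sits. Compound 4 `COc1cc(C2CCN(CC(N)=O)CC2)ccc1Nc1ncc2ccc(-c3ccccc3N(C)S(C)(=O)=O)n2n1` has not yet been measured. It differs from compound 3 by methyl(methylsulfonyl)amino in place of methoxy on an aromatic carbon. Within the data shown here, no measured step covers this exchange, so any expectation rests on looser grounds. Compounds 1 and 2 carry the same methyl(methylsulfonyl)amino group as compound 4 and both gave numbers rather than a limit, though they also differ from compound 4 at the amine nitrogen. Compound 4 is therefore expected to give roughly 0.4 h, between 0.15 h and 1 h. The expected step of an at least 1.6-fold lower number from compound 3 to compound 4 (0.22 log units; that floor lies within the scatter) cannot be sized sharply, since compound 3 is known only as a limit.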

Compound 4, half-life: < 0.0834 h
Compound 4 ended at the assay's limit; the forecaster's own chance of this, stated with the estimate: 25%; at least 4.7-fold (0.68 log units) between middle value and limit.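

At this position, on an aromatic carbon ortho to a large group, putting methyl(methylsulfonyl)amino in place of methoxy clearly shortens the half-life, with an at least 7.9-fold lower number from compound 3 to compound 4 (0.90 log units; beyond the scatter). With methyl(methylsulfonyl)amino kept in place, the group on the amine nitrogen in the ring also counts: carbamoylmethyl in place of hydrogen gives an at least 4.4-fold lower number from compound 2 to compound 4 (0.64 log units; beyond the scatter), and carbamoyl in place of 1-hydroxyethyl gives an at least 2.1-fold lower number from compound 1 to compound 4 (0.34 log units; beyond the scatter). Compound 4 stands at a limit of the assay, so each of these steps is only a floor: the limit of < 0.0834 h in this assay, at which 1 of the 4 values shown sits.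

Going by these compounds, the true distance between the methoxy and methyl(methylsulfonyl)amino compounds stays open, since compound 3 is also a limit: the limit of > 0.666 h in this assay, at which 1 of the 4 values shown sits. Also open, on these data alone, is how a plain amine or a hydroxyl on this aromatic carbon would compare, and whether methoxy would keep its advantage with hydrogen on the ring nitrogen.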